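The source may hold more compounds than are shown below. What is called first, only, known or untested is meant among the compounds shown, and "the series" means these compounds.

Compound 1 `CCc1cn([C@H]2C[C@@H]3OP(=O)(O)OC[C@H]3O2)c(=O)[nH]c1=O` carries an ethyl group on the shared core, and in a functional assay on Raji cells (Homo sapiens) (on this read-out lower numbers stand for stronger inhibition and higher numbers for weaker inhibition), compound 1 gives 60 ug/mL. Compound 2 `CCCCCCc1cn([C@H]2C[C@@H]3OP(=O)(O)OC[C@H]3O2)c(=O)[nH]c1=O` carries a hexyl chain instead, and in this assay compound 2 gives > 500 ug/mL, which is a limit of the assay and not a number. Compound 3 `CCCc1cn([C@H]2C[C@@H]3OP(=O)(O)OC[C@H]3O2)c(=O)[nH]c1=O` carries a propyl chain, and in this assay compound 3 gives > 500 ug/mL, again a limit of the assay. Two of the three values therefore sit at the same limit (the limit of > 500 ug/mL in this assay, at which 2 of the 3 values shown sit). Lengthening the ethyl of compound 1 gave an at least 8.3-fold higher number from compound 1 to compound 3 (0.92 log units; beyond the scatter) and an at least 8.3-fold higher number from compound 1 to compound 2 (0.92 log units; beyond the scatter), while the step between the two limits is a step that the two limits leave unreadable from compound 2 to compound 3.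

Compound 4 `CC(C)c1cn([C@H]2C[C@@H]3OP(=O)(O)OC[C@H]3O2)c(=O)[nH]c1=O` differs from compound 3 by isopropyl in place of propyl on an aromatic carbon; the two have the same atoms, joined differently. Going by the values given here, no measured step changes branching, so the measured steps give only a weak hint: compound 3 stands at the limit and the shape change is small. The step from compound 3 to compound 4 is expected to be a step that the limit leaves unreadable from compound 3 to compound 4. Compound 4 is estimated at 600 ug/mL, with a range from 150 ug/mL to 2000 ug/mL, and most likely the assay will again report only a limit.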

Compound 4, concentration for 50% inhibition: > 500 ug/mL
Compound 4: a limit, no number (the forecaster's own chance of this, stated with the estimate: 70%); the middle value does not contradict the limit.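

Branching shows what the straight chains could not: the isopropyl group of compound 4 has the same atoms as the propyl group of compound 3, yet it also gives only a limit of the assay, not a number, so in this assay this change of chain shape at this position does not restore a readable value. Set against the ethyl group, the extra methyl of the branched chain gives an at least 8.3-fold higher number from compound 1 to compound 4 (0.92 log units; beyond the scatter). The steps among compound 2, compound 3 and compound 4 cannot be read, and these three cannot be ranked: the limit of > 500 ug/mL in this assay, at which 3 of the 4 values shown sit.

Still open, on these data alone, is how a methyl group, a shorter chain than ethyl, would read in this assay at this position. Also open, as far as these compounds go, is whether a group of another kind there, such as an amine or a carboxylic acid, would give a number at all.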